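Swapping Ethylcarbamoyl for Cyclopropylcarbonyl in a Melatonin Series

The compounds below may be only part of what the source reports. "The series", "measured", "known", "first", "only" and "open" are said of these compounds alone.

Compound 1, `COc1ccc2ncnc(NCCNC(C)=O)c2c1`: > 100000 nM
Compound 2, `CCNC(=O)N1CCN(c2ncnc3ccc(OC)cc23)CC1`: > 100000 nM

In an assay on CHO cells for displacement of a labelled ligand from melatonin receptor type 1A (Homo sapiens), read by radioligand binding, with a stated time of 120 min (on this read-out higher numbers stand for weaker inhibition and lower numbers for stronger inhibition), compound 1 gives > 100000 nM, which is a limit of the assay. Compound 2 in this assay gives > 100000 nM, again a limit. Among the measured compounds shown here, compound 2 thus stands exactly where the only other value stands, at the limit of > 100000 nM in this assay, at which 2 of the 2 values shown sit. For the measured compounds named here, nothing separates the two compounds, and no step between them is given, because they differ in more than one place.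

Compound 3, `COc1ccc2ncnc(N3CCN(C(=O)C4CC4)CC3)c2c1`, arises from compound 2 by a single change: cyclopropyl in place of ethylamino on a carbonyl carbon. Going by the values given here, since both values seen so far are limits, there is no measured step to set the size of this one; the expectation is that compound 3 also remains at the limit, with no step beyond the scatter. Compound 3 is therefore expected to give 100000 nM in this assay, within 20000 nM to 300000 nM, an expected step of a number no higher from compound 2 to compound 3 (the limit leaves the size open).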

Compound 3, inhibition constant: > 100000 nM
Compound 3 ended at the assay's limit; the forecaster's own chance of this, stated with the estimate: 80%; the middle value sits exactly at the limit.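

Compound 2 and compound 3 both rest at a limit, so no step can be read for cyclopropyl in place of ethylamino: the limit of > 100000 nM in this assay, at which 3 of the 3 values shown sit.

The compounds shown leave open whether any group on this carbonyl carbon can give a measurable value in this assay.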